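The compounds below may be only part of what the source reports. "The series", "measured", "known", "first", "only" and "open" are said of these compounds alone.

Measured compounds in the series:
- compound 1, `NS(=O)(=O)c1ccccc1-c1cnc(C(=O)CCCCCCc2ccccc2)o1`: 1500 nM
- compound 2, `Nc1cccc(-c2cnc(C(=O)CCCCCCc3ccccc3)o2)c1`: 19 nM

In an assay (Rattus norvegicus) for inhibition of Fatty-acid amide hydrolase 1 (Homo sapiens) (a lower number here means a stronger inhibitor, a higher number a weaker inhibitor), compound 2 gives 19 nM, the lowest of the two numbers. Its nearest neighbour is compound 1, which gives 1500 nM, a gap beyond the scatter. Going by the values given here, no pair of measured compounds differs in only one place, so no single step is available to lean on.

Compound 3, `COc1ccc(-c2cnc(C(=O)CCCCCCc3ccccc3)o2)cc1`, is not yet measured. It differs from compound 2 as follows: 4-methoxyphenyl in place of 3-aminophenyl on an aromatic carbon. The change keeps the aromatic ring and the count of acceptors and removes the one donor. Among the compounds with values here, with no measured step to compare against, only the two values shown can guide the expectation.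

The expectation for the step from compound 2 to compound 3 in this assay is a modest move to a higher number, a 2.1-fold higher number from compound 2 to compound 3 (0.32 log units; beyond the scatter), a step that may or may not exceed the scatter. Compound 3 is therefore estimated to give 40 nM, with a range of 12 nM to 130 nM expected.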

Compound 3, inhibition constant: 100 nM
Beside the measured number, compound 3's estimate is 2.5-fold (0.40 log units) below it; low and high end bracket the measured number.
By their numbers in this assay, from the lowest: compound 2; then compound 3; then compound 1.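

At the aromatic carbon next to the ring oxygen, 4-methoxyphenyl in place of 3-aminophenyl gives a 5.3-fold higher number from compound 2 to compound 3 (0.72 log units; beyond the scatter) in this assay, so this position responds to the aryl substituent even when the aromatic ring stays in place. The hydrogen-bond donor of the 3-aminophenyl group is not needed for a value well under that of compound 1, since compound 3, which has no donor, gives 100 nM, although compound 2 remains the lowest of the three. No measurement in hand accounts for the size of this step.

The step changes the substituent and its place on the phenyl ring together, so the two contributions cannot be separated from these compounds. A 3-methoxyphenyl or 4-aminophenyl group at the same carbon would divide the step into those two parts, and an unsubstituted phenyl would show whether the amino and methoxy groups each raise or lower the number relative to the bare ring.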